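The source may report more compounds than this note shows. Statements on the series, on what has been measured and on what is new or still open speak of the compounds shown alone.

Compound 1 `CCc1oc2ccc(OC)cc2c1C(=O)c1ccc(O)cc1` and compound 2 `CCc1oc2ccc(O)cc2c1C(=O)c1ccc(O)cc1` differ in a single respect: compound 2 carries hydrogen in place of methyl on an oxygen on an aromatic ring. In an assay for inhibition of solute carrier family 22 member 12 (Homo sapiens), read by scintillation counting, with a stated time of 60 min, tested at 50 uM (on this read-out higher numbers stand for more inhibition at the one concentration tested (going by the name of the read-out) and lower numbers for less inhibition), compound 1 gives 92.7% and compound 2 gives 96.5%, so the step of a number 3.8 percentage points higher from compound 1 to compound 2 (within the scatter) stays within the scatter. Compound 3 `CCc1cc2cc(O)cc(C(=O)c3ccc(OC)cc3)c2o1` is built from the same atoms as compound 1, joined differently; the difference between the two cores is not broken down here. In this assay compound 3 gives 9.3%, the lowest of the three numbers, with its gaps to compound 1 and to compound 2 both lying beyond the scatter. Compound 4 `CCc1cc2cc(O)cc(C(=O)c3ccc(O)cc3)c2o1` has not yet been measured. It stands to compound 3 as compound 2 stands to compound 1, carrying (hydrogen in place of methyl on an oxygen on an aromatic ring), at a place described in the same words as before: on an oxygen on an aromatic ring whose other neighbour is aromatic carbon. Compound 4 is expected to differ from compound 3 by a number 5.7 percentage points higher from compound 3 to compound 4 (within the scatter) in this assay, because the same change gave only a number 3.8 percentage points higher from compound 1 to compound 2 (within the scatter). Compound 4 is therefore estimated at 15%, most likely between 0% and 40%.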

Compound 4, a percentage reported as inhibition, at one concentration (the size of the read-out at that concentration, not a potency): 41%
Compound 4: middle estimate off by 26 percentage points, on the low side; measured number outside the range, above it.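

Methoxy to hydroxy gave a number 31.7 percentage points higher from compound 3 to compound 4 (beyond the scatter) in this assay, whereas the same change on the other core gave a number 3.8 percentage points higher from compound 1 to compound 2 (within the scatter), so the size of the step did not carry from one core to the other: the same change on two cores in this assay, a number 3.8 percentage points higher (within the scatter) from compound 1 to compound 2 and a number 31.7 percentage points higher (beyond the scatter) from compound 3 to compound 4, 27.9 percentage points apart, beyond the scatter of two such steps. In this series, then, a step measured on one of these two cores is a poor guide to the size of the same change on the other, even though the place of the change is described in the same words in both pairs. The two pairs do not show why the cores differ, and they offer no rule for any further core; each number is also a single reading at one concentration, not a potency.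

The compounds shown leave open whether an amine or a carboxylic acid in place of the hydroxy would shift the number on either core. As far as these compounds go, whether a longer chain in place of the ethyl would alter the gap between the two steps also remains open.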